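This account rests on a few compounds, and the source may have more. Where it says the series, first, only, none or still open, it means among the compounds named here.

Measured in a functional assay on HT-29 cells (Homo sapiens) for inhibition, read by MTT assay, with a stated time of 72 h; on this read-out higher numbers stand for weaker inhibition and lower numbers for stronger inhibition:

- Compound 1 `CC(C)CNC(=C\C(=O)/C=C/c1ccc(O)cc1)/C=C/c1ccc(O)cc1`: 20100 nM
- Compound 2 `COc1cc(/C=C/C(=O)/C=C(/C=C/c2ccc(OC(C)=O)c(OC)c2)NCC(C)C)ccc1OC(C)=O`: > 25000 nM

Among the measured compounds shown here, compound 1 is the only compound here with a true number, 20100 nM, so it is the single firm reference point. For compound 2, the entry > 25000 nM is a limit of the assay and not a number.

The next compound, compound 3 `CCC(C)NC(=C\C(=O)/C=C/c1ccc(O)cc1)/C=C/c1ccc(O)cc1`, has not yet been measured in this assay. For the measured compounds named here, its only change from compound 1 is sec-butyl in place of isobutyl on an amine nitrogen. The two compounds have the same atoms, joined differently.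

Going by the values given here, no measured pair here shows what a change at this place does, so the expectation has little to rest on beyond compound 1 at 20100 nM. No step beyond the usual scatter is expected in either direction. The expected change, a 1.0-fold lower number from compound 1 to compound 3 (0.00 log units; within the scatter), is therefore small. For compound 3 the estimate is 20000 nM, with an expected range from 9000 nM to 32000 nM.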

Compound 3, half-maximal inhibitory concentration: 13000 nM
Compound 3: middle estimate off by 1.5-fold (0.19 log units), on the high side; measured number inside the range.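

The swap of isobutyl for sec-butyl on the amine nitrogen gives the first step measured at this place in this assay: a 1.5-fold lower number from compound 1 to compound 3 (0.19 log units; within the scatter). Rearranging the carbons of this butyl group, with the atoms themselves unchanged, therefore produces no difference that can be told apart from the ordinary variation between repeated measurements. Compound 2 carries an entry that is a limit and not a number, and that limit shows how close the measured values lie to the top of what this read-out reports: the limit of > 25000 nM in this assay, at which 1 of the 3 values shown sits.

Among the compounds shown here, only two butyl groups have been compared on this nitrogen, so it remains open whether the position responds to a larger change, such as a cyclohexyl ring, a benzyl group or a longer chain ending in a carboxylic acid. Also open, going by these compounds, is whether any group here could bring the number well away from the values seen so far, and whether the small result for this swap would hold on a differently substituted core, such as that of compound 2.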